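The source may hold more compounds than are shown below. What is called first, only, known or untested is meant among the compounds shown, and "the series" means these compounds.

Compound 1 `COc1cc(/C=C/C(=O)c2c(OC)cc(O)c(CC=C(C)C)c2O)ccc1O`: 21700 nM
Compound 2 `COc1cc(O)c(CC=C(C)C)c(O)c1C(=O)/C=C/c1ccc(O)c(O)c1`: 15200 nM

Both compounds were tested in a functional assay on HepG2 cells (Homo sapiens) for inhibition, read by MTT assay, with a stated time of 72 h; a higher number here means a weaker inhibitor, a lower number a stronger inhibitor. On the numbers shown, compound 2 stands alongside compound 1, as the only measured step, a 1.4-fold lower number from compound 1 to compound 2 (0.15 log units; within the scatter), lies within the scatter; the two cannot be told apart on potency.

Compound 3 `COc1cc(O)c(CC=C(C)C)c(O)c1C(=O)/C=C/c1ccc(Cl)cc1` has not yet been measured. It differs from compound 2 in one place: 4-chlorophenyl in place of 3,4-dihydroxyphenyl on a double-bonded chain carbon bound to a double-bonded chain carbon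

Among the compounds with values here, no measured step bears on this change. Within the data shown here, the one step recorded, a 1.4-fold lower number from compound 1 to compound 2 (0.15 log units; within the scatter), concerns a different part of the shared core and was itself within the scatter, so it offers no guide to what exchanging the 3,4-dihydroxyphenyl for a 4-chlorophenyl will do. With nothing to lean on, the plainest expectation is no step beyond the scatter, with a wide range to allow for movement either way.

The estimated step from compound 2 to compound 3 is therefore a 1.2-fold higher number from compound 2 to compound 3 (0.07 log units; within the scatter). Compound 3 is expected to give about 18000 nM in this assay, within a range from 5000 nM to 70000 nM.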

Compound 3, half-maximal inhibitory concentration: 10100 nM
Estimate against measurement, compound 3: 1.8-fold (0.25 log units) above; the measured number falls inside the stated range.
By their numbers in this assay, from the lowest: compounds 3, 2 and 1 (each within the scatter of the next, the first and the last beyond it).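

Exchanging the 3,4-dihydroxyphenyl for a 4-chlorophenyl on the double-bonded chain carbon does not cost potency in this assay even though the ring loses both hydroxyl groups, going from 2 hydrogen-bond donors to 0 (a 1.5-fold lower number from compound 2 to compound 3 (0.18 log units; within the scatter)). Set against the 4-hydroxy-3-methoxyphenyl of compound 1, the same 4-chlorophenyl gives the first step in this small set to pass beyond the scatter, though only modestly (a 2.1-fold lower number from compound 1 to compound 3 (0.33 log units; beyond the scatter)). Nothing measured here explains either step.

From the compounds shown here alone, it remains open whether the chlorine itself matters or whether any ring without hydroxyl groups would serve equally well, a question that a plain phenyl, a 4-fluorophenyl or a 4-aminophenyl at this place could help settle. All three compounds also share the same prenyl-bearing remainder of the core, so the shown steps say nothing about how this result would hold if that chain were replaced by a longer chain or an amine.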